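Replacing the Amino Group on a Selenium-Bearing Quinazoline Core

A few compounds are considered here, and "the series" means these few. Any claim that something is new, unique, unknown or untested is made for them only; others in the source may bear on it.

Measured compounds:
- compound 1 `C[Se]c1nc(N)c2ccccc2n1`: 46500 nM
- compound 2 `Nc1nc([SeH])nc2ccccc12`: 150 nM

In a functional assay on MCF7 cells (Homo sapiens) for cytotoxicity, read by MTT assay, with a stated time of 72 h (on this read-out higher numbers stand for weaker inhibition of growth and lower numbers for stronger inhibition of growth), compound 1 gives 46500 nM, the highest of the two numbers recorded, and compound 2 gives 150 nM. Among the measured compounds shown here, the only measured step, a 310-fold lower number from compound 1 to compound 2 (2.49 log units; beyond the scatter), comes from hydrogen in place of methyl on a selenium; it leaves the amino group untouched.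

Compound 3 `C[Se]c1nc([Se]C)c2ccccc2n1` differs from compound 1 in another place: a group of 2 heavy atoms (1 carbon, 1 selenium; no ring) in place of one nitrogen atom, on an aromatic carbon. For the measured compounds named here, no measured step touches this amino group, so the one large step seen gives no direct guide to it; it only shows that this core can respond strongly to a single small change. With no evidence either way, the expectation for compound 3 is a number near that of compound 1, with wide uncertainty, so the estimated step of a 1.3-fold higher number from compound 1 to compound 3 (0.11 log units; within the scatter) is small. Compound 3 is therefore estimated at 60000 nM, within a range from 12000 nM to 300000 nM.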

Compound 3, concentration for 50% growth inhibition: 5970 nM
Compound 3: middle estimate off by 10-fold (1.00 log units), on the high side; the whole stated range lies above it.
By their numbers in this assay, from the lowest: compound 2; then compound 3; then compound 1.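

Replacing the amino group with a group of 2 heavy atoms (1 carbon, 1 selenium; no ring) on this aromatic carbon does not weaken growth inhibition in this assay; instead, it gives a 7.8-fold lower number from compound 1 to compound 3 (0.89 log units; beyond the scatter). This shows that a second place on the shared core can shift the number, and that the amino group, with its hydrogen-bond donor and acceptor, is not required for the activity of compound 3. No measurement here explains why the number falls.

With a single replacement at this place, the compounds shown leave open whether the selenium, the methyl on it, or the loss of the amino group drives the change. A plain hydrogen, a hydroxyl group or a methylthio group here could help tell these readings apart.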